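The source may hold more compounds than are shown below. What is called first, only, known or untested is meant among the compounds shown, and "the series" means these compounds.

Compound 3 `NC(=O)c1c(NC(=O)c2ccccc2Cl)sc2c1CCN(Cc1ccc(Cl)cc1)C2` sits at a limit of a functional assay on HeLa cells (Homo sapiens) for antiproliferative activity, with a stated time of 24 h; on this read-out lower numbers stand for stronger inhibition and higher numbers for weaker inhibition: in this assay compound 3 gives > 50000 nM, which is a limit and not a number. Compound 1 `NC(=O)c1c(NC(=O)c2ccccc2Cl)sc2c1CCN(Cc1ccccc1Cl)C2` gives 27500 nM in this assay. Compound 2 `NC(=O)c1c(NC(=O)c2ccccc2Cl)sc2c1CCN(Cc1ccccc1F)C2` also reaches a limit, giving > 50000 nM in this assay. Accordingly, (the limit of > 50000 nM in this assay, at which 2 of the 3 values shown sit), and compound 3 is one of the two that sit there. The step to compound 4 `NC(=O)c1c(NC(=O)c2ccccc2Cl)sc2c1CCN(Cc1ccc([N+](=O)[O-])cc1)C2` is nitro in place of chloro on an aromatic carbon. For the measured compounds named here, no measured step replaces chloro with nitro. The measured steps that touch this part of the molecule are an at least 1.8-fold higher number from compound 1 to compound 3 (0.25 log units; that floor lies within the scatter) and an at least 1.8-fold higher number from compound 1 to compound 2 (0.25 log units; that floor lies within the scatter), both ending at a limit and so giving only a floor, while a step that the two limits leave unreadable from compound 2 to compound 3. With its starting point already at a limit, compound 4 is expected to remain near that limit. The step that the limit leaves unreadable from compound 3 to compound 4 is the estimated shift, without a readable direction. Compound 4 is therefore estimated at 60000 nM, between 25000 nM and 150000 nM, and most likely reported only as a limit.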

Compound 4, half-maximal inhibitory concentration: 46100 nM
Compound 4: middle estimate off by 1.3-fold (0.11 log units), on the high side, and the stated range covers the measured number.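

In this assay, the 4-nitrobenzyl group gives compound 4 a readable number, whereas the 4-chlorobenzyl group of compound 3 and the 2-fluorobenzyl group of compound 2 leave only a limit: the limit of > 50000 nM in this assay, at which 2 of the 4 values shown sit.

This is no more than a floor, an at least 1.0-fold lower number from compound 3 to compound 4 (0.03 log units; that floor lies within the scatter) and an at least 1.0-fold lower number from compound 2 to compound 4 (0.03 log units; that floor lies within the scatter), so nitro in place of chloro on this aromatic carbon shows no step beyond the scatter. Against the only other readable value the result is a 1.7-fold higher number from compound 1 to compound 4 (0.22 log units; within the scatter), which also lies within the scatter, so compound 1 and compound 4 cannot be told apart in this assay.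

The compounds shown leave open whether an amine or a carboxylic acid on the same aromatic carbon would give a clearly lower number. They also leave open whether any group at this position moves the read-out beyond the scatter.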